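Swapping the Aryl Group on a Shared Core

The source may report more compounds than this note shows. Statements on the series, on what has been measured and on what is new or still open speak of the compounds shown alone.

Compound 1 `COc1ccc(-c2cn3ccnc3c(-c3ccc4ncn(C5CCCCC5)c4c3)n2)cc1`: in a functional assay on DU-145 cells (Homo sapiens) for inhibition, read by sulforhodamine B assay, with a stated time of 48 h, tested at 10 uM (a lower number here means less inhibition, a higher number more inhibition at the concentration tested (going by the name of the read-out)), compound 1 gives 81.8%.
Compound 2 `c1ccc2c(-c3cn4ccnc4c(-c4ccc5ncn(C6CCCCC6)c5c4)n3)cccc2c1`: in this assay compound 2 gives 5.1%.
Compound 3 `Fc1ccccc1-c1cn2ccnc2c(-c2ccc3ncn(C4CCCCC4)c3c2)n1`: in this assay compound 3 gives 0.96%.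

These three compounds share one core and differ only in the aromatic group attached to it. Compound 3 has the lowest of the three numbers; its nearest neighbour is compound 2, whose number is only slightly higher and within the scatter, while compound 1 stands far above both. The next compound, compound 4 `c1csc(-c2cn3ccnc3c(-c3ccc4ncn(C5CCCCC5)c4c3)n2)c1`, is one step away from compound 3: thiophen-2-yl in place of 2-fluorophenyl on an aromatic carbon.

Two measured steps speak to this kind of change. The step of a number 80.8 percentage points lower from compound 1 to compound 3 (beyond the scatter) and the step of a number 76.7 percentage points lower from compound 1 to compound 2 (beyond the scatter) show that the choice of aromatic group decides almost everything here: only the 4-methoxyphenyl of compound 1 gives strong inhibition, and the other two groups give nearly none. The step of a number 4.1 percentage points lower from compound 2 to compound 3 (within the scatter) shows no difference between those two groups. Thiophen-2-yl, like naphthalen-1-yl and 2-fluorophenyl, carries no methoxy group, so only a small change from compound 3 is expected, although with so few examples a larger rise cannot be excluded. The expected step is a number 14 percentage points higher from compound 3 to compound 4 (beyond the scatter). For compound 4 the estimate in this assay is 15%, with a range from 0% to 60%.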

Compound 4, a percentage reported as inhibition, at one concentration (the size of the read-out at that concentration, not a potency): 5.07%
For compound 4 the middle estimate is 9.9 percentage points above the measured one, and the stated range covers the measured number.
By their numbers in this assay, from the lowest: compounds 3, 4 and 2 (each within the scatter of the next); then compound 1.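

In this assay the change puts a five-membered aromatic ring with one sulfur atom in place of a six-membered aromatic ring of carbon only, yet the result is a number 4.1 percentage points higher from compound 3 to compound 4 (within the scatter) and, set against the naphthalen-1-yl group, a number 0 percentage points lower from compound 2 to compound 4 (within the scatter). Ring size and a hetero atom in the ring therefore do not separate these groups: 2-fluorophenyl, naphthalen-1-yl and thiophen-2-yl all sit together at a low level, while the 4-methoxyphenyl group stands alone, as the step of a number 76.7 percentage points lower from compound 1 to compound 4 (beyond the scatter) shows. No measurement here explains why this one group differs from the other three.

For the compounds shown here, compound 1 is still the only compound with strong inhibition, so it remains open whether the methoxy group itself matters or whether a phenyl ring carrying something at that same place would do as well. A plain phenyl ring, or a phenyl ring bearing a hydroxyl group, an amine or a longer ethoxy chain, would help to separate these possibilities.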